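An Amino Group in Place of Hydrogen on the Shared Core

This account rests on a few compounds, and the source may have more. Where it says the series, first, only, none or still open, it means among the compounds named here.

Compound 1 `ClCc1ccccc1Cn1cnc2c(Cl)nc(Cl)nc21` gives 1730 nM in a functional assay on NCI-H322M cells (Homo sapiens) for cytotoxicity, read by sulforhodamine B assay, with a stated time of 48 h; on this read-out lower numbers stand for stronger inhibition of growth and higher numbers for weaker inhibition of growth.
Compound 2 `ClCc1ccccc1Cn1cnc2c(Cl)ncnc21` gives 3980 nM in this assay.
Compound 3 `ClCc1ccc(Cn2cnc3c(Cl)nc(Cl)nc32)cc1` gives 12600 nM in this assay.

Among these three numbers, compound 2 stands second highest. Compound 1 lies closest to it, and the two differ at a single point: hydrogen in place of chloro on an aromatic carbon, which gave a 2.3-fold higher number from compound 1 to compound 2 (0.36 log units; beyond the scatter). For the measured compounds named here, compound 3 shows the highest number of the three; no single-point step connects it to compound 2, so its value is noted only as it stands.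

Compound 4 `Nc1nc(Cl)c2ncn(Cc3ccccc3CCl)c2n1` has not yet been measured. It differs from compound 2 by amino in place of hydrogen on an aromatic carbon. Going by the values given here, the only measured step that touches this same position of the shared core is the one from compound 1 to compound 2, where removing chloro raised the number by a modest amount. An amino group is a different substituent from chloro, so that step is a guide to the sensitivity of the position rather than to the direction of this change. Reoccupying the position is expected to move the number in this assay by no more than a modest amount, with a lower number somewhat more likely than a higher one.

Compound 4 is therefore estimated at 3000 nM, with a range from 800 nM to 12000 nM. This estimate corresponds to an expected step of a 1.3-fold lower number from compound 2 to compound 4 (0.12 log units; within the scatter).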

Compound 4, concentration for 50% growth inhibition: 12300 nM
Compound 4: middle estimate off by 4.1-fold (0.61 log units), on the low side; the measured number lies above the stated range.
By their numbers in this assay, from the lowest: compound 1; then compound 2; then compounds 4 and 3 (each within the scatter of the next).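

The amino result shows that this position, on an aromatic carbon between two ring nitrogen atoms, does not simply favour any group over hydrogen: in this assay, amino in place of hydrogen gave a 3.1-fold higher number from compound 2 to compound 4 (0.49 log units; beyond the scatter). The earlier step had shown only that losing chloro raised the number, which left open whether a different group would restore a lower one, and amino does the opposite. Set directly against chloro, amino gave a 7.1-fold higher number from compound 1 to compound 4 (0.85 log units; beyond the scatter), so across these three compounds the numbers rise in the order chloro, hydrogen, amino, although the data offered here contain no measurement that accounts for this order.

As far as these compounds go, three groups are too few to show what governs the position, and it remains open where a methyl group, a methoxy group or a fluoro group would fall in this order. Also open is whether the same order would hold with the chloromethyl group placed as it is in compound 3, as that compound has only the chloro form among those shown.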